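The source may hold more compounds than are shown below. What is called first, only, known or untested is meant among the compounds shown, and "the series" means these compounds.

Measured compounds:
compound 1 `Oc1cccc(-c2cc(-c3ccco3)cc(-c3cccc(O)c3)n2)c1` — 1890 nM
compound 2 `Oc1ccc(-c2cc(-c3ccco3)cc(-c3cccc(O)c3)n2)cc1` — 840 nM

In a functional assay on HCT-15 cells (Homo sapiens) for cytotoxicity, read by CCK-8 assay (on this read-out lower numbers stand for stronger inhibition and higher numbers for weaker inhibition), compound 1 gives 1890 nM, the higher of the two numbers. Going by the values given here, compound 2 gives 840 nM, and the only measured step, a 2.3-fold lower number from compound 1 to compound 2 (0.35 log units; beyond the scatter), exchanges one hydroxyphenyl group. Compound 3 `Oc1cccc(-c2cc(-c3cccnc3)cc(-c3cccc(O)c3)n2)c1` differs from compound 1 by pyridin-3-yl in place of furan-2-yl on an aromatic carbon. Among the compounds with values here, no measured step bears on this exchange; the step from compound 1 to compound 2 concerns a different position. The expected step is therefore a 1.2-fold lower number from compound 1 to compound 3 (0.07 log units; within the scatter), not beyond the scatter in either direction. For compound 3 the estimated value in this assay is 1600 nM, with a range from 500 nM to 5000 nM.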

Compound 3, half-maximal inhibitory concentration: > 50000 nM
Compound 3: a limit, no number; the forecaster's own chance of this, stated with the estimate: 5%; middle value at least 31-fold (1.49 log units) away from the limit.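

Going by these compounds alone, the position opposite the ring nitrogen, untouched by the earlier compounds, proves sensitive: in this assay, the exchange of furan-2-yl for pyridin-3-yl gives an at least 26-fold higher number from compound 1 to compound 3 (1.42 log units; beyond the scatter). Compound 3 gives > 50000 nM, which is a limit and not a number: the limit of > 50000 nM in this assay, at which 1 of the 3 values shown sits.

Going by these compounds, whether this loss belongs to the nitrogen of pyridin-3-yl or to the six-membered ring as such stays open, as does how a phenyl or thiophen-2-yl group would read at this position. Also open, on these data alone, is whether the same exchange acts alike with the 4-hydroxyphenyl group of compound 2.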